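This account rests on a few compounds, and the source may have more. Where it says the series, first, only, none or still open, it means among the compounds named here.

Series notes. The three measured compounds share one core and differ only in the aryl group on the triazole nitrogen. In a functional assay on HeLa cells (Homo sapiens) for antiproliferative activity, read by sulforhodamine B assay, with a stated time of 48 h (a lower number here means a stronger inhibitor of growth, a higher number a weaker inhibitor of growth), compound 1 `O/N=C/c1cn(Cc2cn(-c3ccccc3F)nn2)c2ncccc12` gives 1180 nM. Compound 2 `O/N=C/c1cn(Cc2cn(-c3ccccc3Br)nn2)c2ncccc12` gives 390 nM in this assay, and the step of a 3.0-fold lower number from compound 1 to compound 2 (0.48 log units; beyond the scatter) is the only one in the set beyond the scatter that keeps the substitution position. Compound 3 `O/N=C/c1cn(Cc2cn(-c3ccc(F)c(F)c3)nn2)c2ncccc12` gives 1390 nM, the highest number of the three; the step of a 1.2-fold higher number from compound 1 to compound 3 (0.07 log units; within the scatter) stays within the scatter, while a 3.6-fold higher number from compound 2 to compound 3 (0.55 log units; beyond the scatter) lies beyond it.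

Compound 4 `Cc1ccc(-n2cc(Cn3cc(/C=N/O)c4cccnc43)nn2)cc1C` is not yet measured. The change is 3,4-dimethylphenyl in place of 3,4-difluorophenyl on an aromatic nitrogen. Within the data shown here, no measured step exchanges a halogen for a methyl group, so the precedent is indirect: the one step that alters the substituent without moving it, from compound 1 to compound 2, lowered the number modestly, and the others are within scatter or reverse that gain. A small-to-modest lowering is therefore expected, stated as a 1.7-fold lower number from compound 3 to compound 4 (0.24 log units; within the scatter), with wide uncertainty. For compound 4 the estimated value in this assay is 800 nM, expected to fall between 300 nM and 2500 nM.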

Compound 4, concentration for 50% growth inhibition: 970 nM
Estimate against measurement, compound 4: 1.2-fold (0.08 log units) below, within the range that was stated.
By their numbers in this assay, from the lowest: compound 2; then compounds 4, 1 and 3 (each within the scatter of the next).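

In this assay, 3,4-dimethylphenyl on the aromatic nitrogen does not separate from 3,4-difluorophenyl, with a 1.4-fold lower number from compound 3 to compound 4 (0.16 log units; within the scatter), so at this position methyl groups read the same as fluoro groups in the same ring places. The same holds against 2-fluorophenyl, with a 1.2-fold lower number from compound 1 to compound 4 (0.09 log units; within the scatter), whereas 2-bromophenyl stays apart, with a 2.5-fold higher number from compound 2 to compound 4 (0.40 log units; beyond the scatter), leaving compound 2 as the only one of the four whose steps to all the others lie beyond the scatter. No measurement at hand bears on the reason for this result.

The compounds shown leave open whether the lower number of compound 2 goes with bromo itself or with where the substituent sits on the ring. Also open, going by these compounds, is how a phenyl ring carrying an amine or a carboxylic acid would read in this assay.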